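The source may hold more compounds than are shown below. What is called first, only, known or untested is meant among the compounds shown, and "the series" means these compounds.

Three amides on a shared core have been tested in a functional assay on SK-OV-3 cells (Homo sapiens) for antiproliferative activity, read by MTT assay, with a stated time of 72 h; a lower number here means a stronger inhibitor, a higher number a weaker inhibitor: compound 1 (`CCNC(=O)CCc1cccc2c1B(O)OC2`), compound 2 (`CC(C)(C)NC(=O)CCc1cccc2c1B(O)OC2`) and compound 3 (`O=C(CCc1cccc2c1B(O)OC2)NCc1ccccc1`). Compound 1 gives > 100000 nM as a limit, not a number. Compound 2 gives > 100000 nM as a limit too. Compound 3, the starting point here, gives > 100000 nM as a limit as well, so it has no readable position. The whole set stands at one bound (the limit of > 100000 nM in this assay, at which 3 of the 3 values shown sit).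

Compound 4 (`O=C(CCc1cccc2c1B(O)OC2)Nc1ccc(Br)cc1`) carries 4-bromophenyl in place of benzyl on an amide-type nitrogen. The measured steps that bear on this change are a step that the two limits leave unreadable from compound 2 to compound 3 and a step that the two limits leave unreadable from compound 1 to compound 2 and a step that the two limits leave unreadable from compound 1 to compound 3 and none offers a size to carry over. Only a loose expectation is therefore possible: a readable value would lie on the stronger side, while another limit remains quite likely. The expected change is an at least 3.3-fold lower number from compound 3 to compound 4 (0.52 log units; beyond the scatter) and it is highly uncertain. Compound 4 is estimated at 30000 nM with a wide expected range (500 nM to 100000 nM).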

Compound 4, half-maximal inhibitory concentration: 9200 nM
Beside the measured number, compound 4's estimate is 3.3-fold (0.51 log units) above it; measured number inside the range.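

In this assay, the amide-type nitrogen turns out to be a place where the substituent can bring a readable response: 4-bromophenyl in place of benzyl gives an at least 10-fold lower number from compound 3 to compound 4 (1.03 log units; beyond the scatter). The same holds against the two alkyl amides, with an at least 10-fold lower number from compound 2 to compound 4 (1.03 log units; beyond the scatter) and an at least 10-fold lower number from compound 1 to compound 4 (1.03 log units; beyond the scatter). Compound 4 alone carries a number, and the steps among compound 1, compound 2 and compound 3 cannot be read, as those three stay at one limit: the limit of > 100000 nM in this assay, at which 3 of the 4 values shown sit.

The compounds shown leave open whether the bromine or the change from benzyl to an aromatic ring on the nitrogen carries this step; a plain phenyl on the amide-type nitrogen would separate the two. As far as these compounds go, how a 4-chlorophenyl or 4-methoxyphenyl group would compare at this place also remains open.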